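The compounds below may be only part of what the source reports. "The series", "measured", "known", "first", "only" and "open" are said of these compounds alone.

Working notes on the series. For the measured compounds named here, in a functional assay on the whole organism (Pleural cavity) with Rattus norvegicus as the target (a lower number here means that less compound is needed, a higher number that more compound is needed for the effect), compound 2 `Sc1[nH]ccc2ncnc1-2` gives 8 mg/kg, the lowest of the two numbers so far, though its nearest neighbour sits within the scatter. In this assay compound 3 `OC[C@H]1OC(n2cnc3c(S)nccc32)[C@H](O)[C@@H]1O` gives 9 mg/kg, within the scatter of compound 2. Compound 1 `OC[C@H]1O[C@@H](n2cnc3c(NCc4ccccc4)nccc32)C[C@@H]1O` returns only a limit in this assay, > 9 mg/kg, as recorded in the limit of > 9 mg/kg in this assay, at which 1 of the 3 values shown sits. Going by the values given here, no pair of measured compounds differs in a single place, so no measured step exists. Compound 4 `Nc1[nH]ccc2ncnc1-2` is yet to be measured; it differs from compound 2 in one place: amino in place of sulfanyl on an aromatic carbon. Among the compounds with values here, with no measured step to lean on, no change beyond the scatter is expected in this assay for this exchange. For compound 4 the estimate in this assay is 8 mg/kg, ranging from 4 mg/kg to 16 mg/kg. This estimate implies an expected step of no change at the digits printed from compound 2 to compound 4 (within the scatter).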

Compound 4, dose for half-maximal effect: 8 mg/kg
For compound 4 middle estimate and measured number coincide at the digits printed, and the stated range covers the measured number.
By their numbers in this assay, from the lowest: compounds 2, 4 and 3 (each within the scatter of the next).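

For the compounds shown here, the first readable step in this assay shows no change at the digits printed from compound 2 to compound 4 (within the scatter), for amino in place of sulfanyl on an aromatic carbon next to the ring nitrogen. On the shared core, this position therefore does not separate these two groups, which enter and leave with equal counts of hydrogen-bond donors and acceptors. No measured property bears on this exchange.

As far as these compounds go, whether a carboxylic acid, a methyl group or a longer chain at this position would give a similar number stays open. So does whether amino in place of sulfanyl would read the same on the core of compound 3.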